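A Methoxy Added to an Amide Sitting at the Assay Limit

The source may report more compounds than this note shows. Statements on the series, on what has been measured and on what is new or still open speak of the compounds shown alone.

Compound 1 `COc1cc(N(C)C(=O)c2ccccc2)cc(OC)c1OC` was examined in a functional assay on Daoy cells (Homo sapiens) for cytotoxicity, read by MTT assay, with a stated time of 72 h; a lower number here means a stronger inhibitor, a higher number a weaker inhibitor. In this assay compound 1 gives >= 125000 nM, which is a limit of the assay and not a number. Compound 2 `COc1cc(N(C)C(=O)N(C)c2cccc(F)c2)cc(OC)c1OC` was run alongside. In this assay compound 2 gives >= 125000 nM, again a limit rather than a measured figure. Compound 1 thus stands only at the boundary of what this assay reports, and all that is known of this series is the limit of >= 125000 nM in this assay, at which 2 of the 2 values shown sit. Compound 3 `COc1ccc(C(=O)N(C)c2cc(OC)c(OC)c(OC)c2)cc1` has not yet been measured in this assay. It differs from compound 1 by methoxy in place of hydrogen on an aromatic carbon. Within the data shown here, no step between measured compounds exists to lean on; with both known values at the limit, no step beyond the usual scatter is expected in this assay, and the outcome will most likely again be a limit. Compound 3 is estimated to give 125000 nM, within a range from 40000 nM to 300000 nM. This corresponds to an expected step of a number no higher from compound 1 to compound 3 (the limit leaves the size open).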

Compound 3, half-maximal inhibitory concentration: >= 125000 nM
Compound 3 gave a limit, no number; the forecaster's own chance of this, stated with the estimate: 85%; the middle value sits exactly at the limit.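

In this assay compound 3 gives >= 125000 nM, which is a limit of the assay and not a number. Among these compounds, compound 1 and compound 3 both stand at such a limit, so no step between them can be read. The compounds shown leave open what their actual values are and whether any change to the shared core would give a measurable value.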